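Methyl for Fluoro on a Shared Core: Expecting Compound 3

The compounds below may be only part of what the source reports. "The series", "measured", "known", "first", "only" and "open" are said of these compounds alone.

Of the compounds shown here, two have been measured in an assay on isolated protein for inhibition of tyrosine-protein kinase receptor UFO (Homo sapiens), read by FRET and Z'-LYTE, with a stated time of 1.5 h; a higher number here means a weaker inhibitor, a lower number a stronger inhibitor. Compound 1 `Cc1c(C(=O)Nc2ccc(Oc3ncnc4[nH]cc(-c5ccccc5)c34)c(F)c2)c(=O)c2c(Cl)cccc2n1C` and compound 2 `Cc1c(C(=O)Nc2ccc(Oc3ncnc4[nH]cc(-c5ccccc5)c34)c(F)c2)c(=O)c2cc(F)ccc2n1C` share the same core and differ only in the substituent on the fused ring. In this assay compound 1 gives > 10000 nM, which is a limit of the assay and not a number. In this assay compound 2 likewise gives > 10000 nM, again a limit of the assay rather than a measured number. Within the data shown here, compound 2 therefore stands at the limit of > 10000 nM in this assay, at which 2 of the 2 values shown sit, and no step between measured compounds can be stated; the two values show only that neither compound reached a measurable concentration.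

Compound 3 `Cc1ccc2c(c1)c(=O)c(C(=O)Nc1ccc(Oc3ncnc4[nH]cc(-c5ccccc5)c34)c(F)c1)c(C)n2C` differs from compound 2 by methyl in place of fluoro on an aromatic carbon. Among the measured compounds shown here, with no measured step to lean on, the expected step from compound 2 to compound 3 is none beyond the scatter, a step that the limit leaves unreadable from compound 2 to compound 3. Compound 3 is accordingly estimated at 20000 nM in this assay, within a range of 6000 nM to 60000 nM, and most likely it will again be reported only as a limit.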

Compound 3, half-maximal inhibitory concentration: 100 nM
Compound 3: middle estimate off by 200-fold (2.30 log units), on the high side, and the stated range ends above it.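

The aromatic carbon that carries fluoro in compound 2 is not a silent place on the shared core: in this assay, methyl in place of fluoro gives an at least 100-fold lower number from compound 2 to compound 3 (2.00 log units; beyond the scatter). The exchange is small in what is counted, one heavy atom for one heavy atom, with no hydrogen-bond donor or acceptor and no net charge on either side, yet it is enough to turn a limit into a measured number, and compound 3 is the only compound shown that has one. The step can be read in one direction only, and its full size stays unknown, because the value of compound 2 is a limit of the assay and not a number: the limit of > 10000 nM in this assay, at which 2 of the 3 values shown sit.

A single pair cannot tell whether the difference belongs to the arrival of methyl or to the departure of fluoro, and the compounds shown do not say how an ethyl or a methoxy group would read on this same aromatic carbon. Nor do they show whether an amine there would match compound 3 at 100 nM.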